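Swapping the fluorophenyl arm: compound 4 under cytotoxicity

The source may report more compounds than this note shows. Statements on the series, on what has been measured and on what is new or still open speak of the compounds shown alone.

Compound 1 `O=c1nc(NCc2cccc(F)c2)oc2c([N+](=O)[O-])cc(C(F)(F)F)cc12` was examined in an ADME assay on Vero cells (Chlorocebus sabaeus) for cytotoxicity, read by MTT assay, with a stated time of 48 h; a higher number here means a weaker inhibitor, a lower number a stronger inhibitor. In this assay compound 1 gave only a limit, > 64 ug/mL. Two companions share the same measurement. Compound 3 `O=c1cc(NCc2ccccc2)sc2c([N+](=O)[O-])cc(C(F)(F)F)cc12` likewise returned only a limit in this assay, > 64 ug/mL. Compound 2 `CC1CN(c2nc(=O)c3cc(C(F)(F)F)cc([N+](=O)[O-])c3o2)CCN1CC1CCCCC1` gave a number in this assay, 10.9 ug/mL. Compound 1 therefore stands among the compounds that were not resolved: of the three values shown, two sit at the limit, as described by the limit of > 64 ug/mL in this assay, at which 2 of the 3 values shown sit, and only compound 2 lies within the measured range.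

Compound 4 `O=c1nc(NCc2ccc3c(c2)OCCO3)oc2c([N+](=O)[O-])cc(C(F)(F)F)cc12` differs from compound 1 in one place: 2,3-dihydro-1,4-benzodioxin-6-yl in place of 3-fluorophenyl on a saturated chain carbon bound to a nitrogen on an aromatic ring. Among the compounds with values here, no pair among the measured compounds differs by a single change, so no measured step guides the expectation, and the data give no measured property of either group. The author expects the step from compound 1 to compound 4 in this assay to be small, a step that the limit leaves unreadable from compound 1 to compound 4, staying within the scatter rather than moving clearly in either direction. Compound 4 is accordingly estimated at 70 ug/mL in this assay, with a range from 30 ug/mL to 150 ug/mL, and it is expected that the assay may once more report only a limit for compound 4.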

Compound 4, half-maximal inhibitory concentration: 25.3 ug/mL
Compound 4: the middle estimate sits 2.8-fold (0.44 log units) above what was measured, outside the stated range (below it).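

In this assay, the place on a saturated chain carbon bound to a nitrogen on an aromatic ring proves able to shift the read-out: 2,3-dihydro-1,4-benzodioxin-6-yl in place of 3-fluorophenyl gives an at least 2.5-fold lower number from compound 1 to compound 4 (0.40 log units; beyond the scatter), a step beyond the scatter. Within the data shown here, the earlier compounds offered no single-change step at all, so this is the first evidence that a change at this place alone can register in this assay, and that it can bring a compound from a limit to a resolved number. The step can be read only as a minimum, since one of its ends is a limit: the limit of > 64 ug/mL in this assay, at which 2 of the 4 values shown sit.

The compounds shown do not separate which part of the change carries the step, whether the loss of the fluorine, the arrival of the two oxygens or the added non-aromatic ring. On these data alone, whether a pyridyl or a thienyl ring at the same place would also move the number in this assay remains open, as does whether the same change would act alike on another core.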